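Swapping the Aryl Group on the Amide Carbonyl

The compounds below may be only part of what the source reports. "The series", "measured", "known", "first", "only" and "open" are said of these compounds alone.

Of the compounds shown here, three built on one shared core have been tested in a functional assay on GTL 16 cells for antiproliferative activity against GTL 16 cell line (Homo sapiens), read by CCK-8 assay, with a stated time of 72 h; on this read-out lower numbers stand for stronger inhibition and higher numbers for weaker inhibition. Compound 1 `Cc1ccccc1C(=O)Nc1cccc(-c2oc3cc(-c4ccc(F)cc4)ccc3c(=O)c2O)c1` gives 24800 nM. Compound 2 `O=C(Nc1cccc(-c2oc3cc(-c4ccc(F)cc4)ccc3c(=O)c2O)c1)c1ccc(C(F)(F)F)cc1` gives 33000 nM. Compound 3 `O=C(Nc1cccc(-c2oc3cc(-c4ccc(F)cc4)ccc3c(=O)c2O)c1)c1cccc(F)c1` gives 15800 nM, the lowest of the three numbers, although the steps of a 1.6-fold lower number from compound 1 to compound 3 (0.20 log units; within the scatter) and a 2.1-fold lower number from compound 2 to compound 3 (0.32 log units; beyond the scatter) show that only one of the two gaps is beyond the scatter. Compound 4 `CCc1ccc(C(=O)Nc2cccc(-c3oc4cc(-c5ccc(F)cc5)ccc4c(=O)c3O)c2)cc1` has not yet been measured; it differs from compound 3 by 4-ethylphenyl in place of 3-fluorophenyl on a carbonyl carbon. All earlier changes at this carbonyl were swaps of the aryl group and moved the read-out little, as in a 1.3-fold higher number from compound 1 to compound 2 (0.12 log units; within the scatter). The step to compound 4 is therefore expected to be small, a 1.3-fold higher number from compound 3 to compound 4 (0.10 log units; within the scatter). For compound 4 in this assay the estimate is 20000 nM, with a range from 8000 nM to 50000 nM.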

Compound 4, half-maximal inhibitory concentration: 24600 nM
Beside the measured number, compound 4's estimate is 1.2-fold (0.09 log units) below it; the measured number falls inside the stated range.
By their numbers in this assay, from the lowest: compounds 3, 4, 1 and 2 (each within the scatter of the next, the first and the last beyond it).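

Ethyl in place of trifluoromethyl on the same aromatic carbon gives a step within the scatter (a 1.3-fold lower number from compound 2 to compound 4 (0.13 log units; within the scatter)), so these two groups cannot be told apart here. The steps from the other two amides are also within the scatter (a 1.6-fold higher number from compound 3 to compound 4 (0.19 log units; within the scatter); a 1.0-fold lower number from compound 1 to compound 4 (0.00 log units; within the scatter)), so compound 4 joins the earlier aryl amides without separating from any of them. No measured evidence explains this insensitivity.

Still open, from the compounds shown here alone, is whether an amine or a carboxylic acid on this aryl ring, or a longer chain in place of ethyl, would move the number beyond the scatter.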